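Notes on the step from compound 2 to compound 3

The source may hold more compounds than are shown below. What is called first, only, known or untested is meant among the compounds shown, and "the series" means these compounds.

Two compounds in this series carry numbers. Compound 1 `O=C(/N=C(/NC(=O)c1csc([N+](=O)[O-])c1)[Se]Cc1ccccc1)c1csc([N+](=O)[O-])c1` gives 23500 nM in a functional assay on K562 cells (Homo sapiens) for cytotoxicity, read by MTT assay, with a stated time of 72 h; on this read-out lower numbers stand for stronger inhibition of growth and higher numbers for weaker inhibition of growth. Compound 2 `C[Se]/C(=N\C(=O)c1cnc2ccccc2c1)NC(=O)c1cnc2ccccc2c1` gives 3800 nM in this assay and holds the lower of the two numbers; the gap to compound 1 lies beyond the usual scatter, and the two differ in more than one place, so no single change can be read from them.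

Compound 3 `CS/C(=N\C(=O)c1cnc2ccccc2c1)NC(=O)c1cnc2ccccc2c1` is not yet measured. It differs from compound 2 by a group of 2 heavy atoms (1 carbon, 1 sulfur; no ring) in place of a group of 2 heavy atoms (1 carbon, 1 selenium; no ring), on a carbon with a double bond to nitrogen. For the measured compounds named here, no measured pair shows this exchange, so its size is open. The expected step is a 2.4-fold higher number from compound 2 to compound 3 (0.37 log units; beyond the scatter), a move toward a higher number just past the scatter. Compound 3 is therefore estimated at 9000 nM, with a range of 3000 nM to 30000 nM.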

Compound 3, concentration for 50% growth inhibition: 65800 nM
Beside the measured number, compound 3's estimate is 7.3-fold (0.86 log units) below it, and the stated range ends below it.
By their numbers in this assay, from the lowest: compound 2; then compound 1; then compound 3.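

In this assay, for the compounds shown here, the exchange of the selenium-bearing group for methylsulfanyl, on a carbon with a double bond to nitrogen whose other neighbours are amide-type nitrogens, gives a 17-fold higher number from compound 2 to compound 3 (1.24 log units; beyond the scatter) and is the first single change that can be read. With the rest of the structure held fixed, this position is clearly not silent: the step is large, and it comes from replacing selenium with sulfur in a group of the same heavy-atom count. Nothing available explains the size of this step.

On these data alone, whether the exchange has a similar size on a different core, such as that of compound 1, stays open. So does how a methoxy group, an amine or a longer chain on selenium would behave at this carbon.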